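The compounds below may be only part of what the source reports. "The series", "measured", "known", "first", "only" and "open" are said of these compounds alone.

Three compounds share a core in which a five-membered ring with three nitrogens carries a (benzoylmethyl)sulfanyl group and a methoxy-substituted phenyl ring. Compound 1 `COc1ccc(-c2nnc(SCC(=O)c3ccccc3)n2-c2ccccc2)cc1OC` has a phenyl on the ring nitrogen; in a functional assay on the whole organism (strain albino) for inhibition, with Rattus norvegicus as the target, read by paw edema, with a stated time of 5 h, at a dose of 0.28 mmol/kg by the oral route (a higher number here means more inhibition at the dose given (going by the name of the read-out), a lower number less inhibition), compound 1 gives 59%. Compound 2 `CCn1c(SCC(=O)c2ccccc2)nnc1-c1cc(OC)c(OC)c(OC)c1` carries an ethyl there, and in this assay compound 2 gives 59%. Compound 3 `C=CCn1c(SCC(=O)c2ccccc2)nnc1-c1cc(OC)c(OC)c(OC)c1` carries an allyl, and in this assay compound 3 gives 60%. On these numbers compound 3 stands level with the other two: its reading and those of compound 1 and compound 2 lie within the usual scatter of one another.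

Compound 4 `COc1cc(-c2nnc(SCC(=O)c3ccccc3)n2-c2ccccc2)cc(OC)c1OC` is not yet measured. It differs from compound 3 in one place: phenyl in place of allyl on an aromatic nitrogen. For the measured compounds named here, the only measured step that touches the same place is the change from methyl to vinyl on the chain carbon bound to the aromatic nitrogen, which gave a number 1 percentage points higher from compound 2 to compound 3 (within the scatter). Compound 1, which also carries a phenyl on the ring nitrogen, gives a reading in the same band as compound 3. A step of no size beyond the scatter is therefore expected, a number 1 percentage points lower from compound 3 to compound 4 (within the scatter). For compound 4 in this assay the estimate is 59%, expected to fall between 49% and 69%.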

Compound 4, a percentage reported as inhibition, in the whole organism at one dose (the size of the read-out at that dose, not a potency): 72%
Beside the measured number, compound 4's estimate is 13 percentage points below it, and the stated range ends below it.
By their numbers in this assay, from the lowest: compounds 1, 2 and 3 (each within the scatter of the next); then compound 4.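

In this assay, the group on the aromatic nitrogen turns out to matter after all: phenyl in place of allyl gives a number 12 percentage points higher from compound 3 to compound 4 (beyond the scatter), and phenyl in place of ethyl gives a number 13 percentage points higher from compound 2 to compound 4 (beyond the scatter), whereas the change from ethyl to allyl gave only a number 1 percentage points higher from compound 2 to compound 3 (within the scatter). The phenyl is not the whole story, since keeping it and putting methoxy in place of hydrogen on an aromatic carbon gives a number 13 percentage points higher from compound 1 to compound 4 (beyond the scatter), so a change at either of these two places separates compound 4 from a compound at the level of the others, and compound 4 reads highest of the four. Nothing measured here explains why these changes raise the number.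

The compounds shown leave open whether the gain needs an aromatic ring on that nitrogen or would also appear with a cyclohexyl, a benzyl or a longer chain there, and whether a hydroxy group could stand in for the added methoxy. On these data alone, each reading is also the size of the effect at one dose and one time, so how the compounds would rank at other doses remains unknown.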